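From 3,5-Dimethoxyphenyl to 4-Methylphenyl on a Shared Core

The compounds below may be only part of what the source reports. "The series", "measured", "known", "first", "only" and "open" are said of these compounds alone.

Of the compounds shown here, two built on a shared core have been measured so far. In a functional assay on HepG2 cells (Homo sapiens) for antiproliferative activity, read by MTT assay, with a stated time of 48 h (a higher number here means a weaker inhibitor, a lower number a stronger inhibitor), compound 1 `COc1ccc(-c2ccc3c(c2)C(=O)C(=O)N3Cc2cccc(OC)c2)cc1` gives 700 nM and compound 2 `COc1ccc(CN2C(=O)C(=O)c3cc(-c4cc(OC)cc(OC)c4)ccc32)cc1` gives 1200 nM as its half-maximal inhibitory concentration. These two numbers lie within the usual scatter of each other, so compound 2 stands level with compound 1 and the pair cannot be ranked. Within the data shown here, no two measured compounds differ in one place only, which leaves no single change with a measured effect to draw on.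

Compound 3 `COc1ccc(CN2C(=O)C(=O)c3cc(-c4ccc(C)cc4)ccc32)cc1` keeps the core and the remainder of compound 2 but carries 4-methylphenyl in place of 3,5-dimethoxyphenyl on an aromatic carbon, meta to a fused ring and para to a fused ring (4-methylphenyl in place of 3,5-dimethoxyphenyl on an aromatic carbon). With only compound 2 (1200 nM) and compound 1 (700 nM) as guides, no step beyond the scatter is expected in this assay and neither direction is favoured. The expected step of a 1.2-fold lower number from compound 2 to compound 3 (0.08 log units; within the scatter) is therefore small. Compound 3 is estimated at 1000 nM (expected range 350 nM to 3000 nM).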

Compound 3, half-maximal inhibitory concentration: > 10000 nM
Compound 3: a limit, no number; the forecaster's own chance of this, stated with the estimate: 3%; middle value at least 10-fold (1.00 log units) away from the limit.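

Among these compounds, the aromatic carbon meta to a fused ring and para to a fused ring proves sensitive to the group it carries: in this assay, 4-methylphenyl in place of 3,5-dimethoxyphenyl gives an at least 8.3-fold higher number from compound 2 to compound 3 (0.92 log units; beyond the scatter), the first single change with a measured effect beyond the scatter. The reading for compound 3 is a limit of the assay and not a number, so the step has a lower bound but no known full size: the limit of > 10000 nM in this assay, at which 1 of the 3 values shown sits. The two groups differ in more than one respect, since 3,5-dimethoxyphenyl has 2 hydrogen-bond acceptors and 4-methylphenyl has 0, and their substituents also sit at different places on the ring, so this single step cannot show which difference matters.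

On these data alone, it remains open how 3,5-dimethylphenyl, which would keep the placement of the two substituents without their oxygen atoms, or 3,5-dihydroxyphenyl, which would keep those oxygen atoms as hydroxyl groups, would read at this carbon. Also open, as far as these compounds go, is whether the same change would have a step of similar size with a different group on the ring nitrogen of the shared core.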